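The source may report more compounds than this note shows. Statements on the series, on what has been measured and on what is new or still open speak of the compounds shown alone.

Among the measured compounds shown here, in an ADME assay on MT4 cells (Homo sapiens) for cytotoxicity, read by MTT assay, with a stated time of 96 h (a lower number here means that less compound is tolerated, a higher number that more compound is tolerated), compound 3 `NS(=O)(=O)c1ccc(N2N=C(c3ccc(OCc4ccccc4)cc3)CC2c2ccccc2Cl)cc1` gives 26000 nM, the only true number so far. Compound 1 `Cc1ccccc1C1CC(c2ccc(OCc3ccccc3)cc2)=NN1c1ccc(S(N)(=O)=O)cc1` reads >= 100000 nM, which is a limit. Compound 2 `NS(=O)(=O)c1ccc(N2N=C(c3ccc(OCc4ccccc4)cc3)CC2c2ccccc2)cc1` reads > 100000 nM, also a limit. Compound 4 `NS(=O)(=O)c1ccc(N2N=C(c3ccc(OCc4ccccc4)cc3)CC2c2ccc(Cl)cc2)cc1` keeps the chloro group but carries 4-chlorophenyl in place of 2-chlorophenyl on a saturated ring carbon. For the measured compounds named here, two measured steps bear on this: an at least 3.8-fold lower number from compound 2 to compound 3 (0.58 log units; beyond the scatter) and an at least 3.8-fold lower number from compound 1 to compound 3 (0.58 log units; beyond the scatter). Both are bounded by limits, and neither tests where the chloro group sits. No step beyond the scatter is therefore expected in this assay, and the estimated step is a 1.2-fold higher number from compound 3 to compound 4 (0.06 log units; within the scatter). For compound 4 the expected value is 30000 nM, with an estimated range of 11000 nM to 85000 nM.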

Compound 4, half-maximal cytotoxic concentration: 70000 nM
Compound 4: the middle estimate sits 2.3-fold (0.37 log units) below what was measured; the range from low to high includes it.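

In this assay, replacing 2-chlorophenyl with 4-chlorophenyl on the saturated ring carbon gives a readable change: a 2.7-fold higher number from compound 3 to compound 4 (0.43 log units; beyond the scatter). Among the compounds shown here, the placement of the chloro group on this phenyl therefore counts here, which the earlier steps did not test. Against the compounds without chloro, only floors can be read: an at least 1.4-fold lower number from compound 2 to compound 4 (0.15 log units; that floor lies within the scatter) and an at least 1.4-fold lower number from compound 1 to compound 4 (0.15 log units; that floor lies within the scatter).

Open, as far as these compounds go, is how 4-fluorophenyl or 4-aminophenyl on the same carbon would read. Also open, from the compounds shown here alone, is whether a gap like that between 2-chlorophenyl and 4-chlorophenyl recurs with a methoxy group.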